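Cyano in Place of Hydrogen: Estimating Compound 4

The source may hold more compounds than are shown below. What is called first, only, known or untested is meant among the compounds shown, and "the series" means these compounds.

Three compounds have been measured in an assay on cells for agonist activity at ecdysone receptor (Bombyx mori), read by a luciferase reporter, with a stated time of 24 h; on this read-out higher numbers stand for an effect only at larger amounts of compound and lower numbers for an effect already at smaller amounts:

compound 1, `CC(C)(C)N(NC(=O)c1ccccc1)C(=O)c1ccccc1Cl`, gives 75.9 nM;
compound 2, `CC(C)(C)N(NC(=O)c1cccc(F)c1)C(=O)c1ccccc1Cl`, gives 69.2 nM;
compound 3, `CC(C)(C)N(NC(=O)c1ccc(Cl)cc1)C(=O)c1ccccc1Cl`, gives 115 nM.

Compound 1 stands second highest of these three numbers, with compound 2 nearest and compound 3 furthest, and both gaps lie within the scatter of this assay. The unmeasured compound 4, `CC(C)(C)N(NC(=O)c1ccc(C#N)cc1)C(=O)c1ccccc1Cl`, differs from compound 1 in a single place: cyano in place of hydrogen on an aromatic carbon.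

Among the measured compounds shown here, two measured steps bear on this change, since both also add a small group to the same aromatic ring of the shared core. The step of a 1.1-fold lower number from compound 1 to compound 2 (0.04 log units; within the scatter) and the step of a 1.5-fold higher number from compound 1 to compound 3 (0.18 log units; within the scatter) both stay within the scatter, so neither a fluoro nor a chloro group on that ring shifted the number in this assay meaningfully. The step of a 1.7-fold higher number from compound 2 to compound 3 (0.22 log units; within the scatter) likewise stays within the scatter. Nothing among these steps suggests that a cyano group would behave very differently, so no step beyond the scatter is expected for compound 4, with a slight lean toward a higher number, as seen with compound 3.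

Compound 4 is therefore estimated at 100 nM, within a range of 45 nM to 220 nM, which means an expected step of a 1.3-fold higher number from compound 1 to compound 4 (0.12 log units; within the scatter).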

Compound 4, half-maximal effective concentration: 603 nM
Compound 4: middle estimate off by 6.0-fold (0.78 log units), on the low side; measured number outside the range, above it.
By their numbers in this assay, from the lowest: compounds 2, 1 and 3 (each within the scatter of the next); then compound 4.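

In this assay, the step of a 7.9-fold higher number from compound 1 to compound 4 (0.90 log units; beyond the scatter) is the first among these compounds to go beyond the scatter, so adding a group to this ring of the shared core is not always without consequence. Exchanging only the group on the same aromatic carbon gives a 5.2-fold higher number from compound 3 to compound 4 (0.72 log units; beyond the scatter), which shows that this place does not treat all added groups alike: chloro there stayed within the scatter of hydrogen, whereas cyano did not. The step of an 8.7-fold higher number from compound 2 to compound 4 (0.94 log units; beyond the scatter) changes both the group and where it sits, and it too lies beyond the scatter, so compound 4 stands apart from all three other compounds with the highest number and thus the largest amount needed for an effect.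

No measurement shown here explains why cyano and chloro part ways at this place. As far as these compounds go, it stays open whether an amine, a carboxylic acid or a longer chain on this carbon would stay close to compound 3 or move as far as compound 4, and whether cyano on another carbon of the ring would give a step of similar size.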